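The compounds below may be only part of what the source reports. "The series", "measured", "known", "first", "only" and "open" are said of these compounds alone.

Measured compounds in an assay on isolated protein for binding affinity to leukotriene B4 receptor 1 (Homo sapiens), tested at 1 uM; on this read-out lower numbers stand for less inhibition and higher numbers for more inhibition at the one concentration tested (going by the name of the read-out): compound 1 `CCc1cc(C(C)=O)c(O)cc1OCCCCC#N` gives 57%; compound 2 `CCc1cc(C(C)=O)c(O)cc1OCCCCCCC(C)(C)C#N` gives 30%; compound 3 `CCc1cc(C(C)=O)c(O)cc1OCCCC(C)(C)C(N)=O` gives 51%.

Compound 2 stands lowest of the three in this assay, with compound 3 its nearest neighbour and compound 1 furthest, both beyond the scatter. Compound 4 `CCc1cc(C(C)=O)c(O)cc1OCCCCCCC(C)(C)c1nnn[nH]1` differs from compound 2 by 1H-tetrazol-5-yl in place of cyano on a saturated chain carbon bound to three saturated chain carbons. For the measured compounds named here, no measured step exchanges a nitrile for a tetrazole. The closest comparison is the step from compound 1 to compound 3, where a carbamoyl-bearing group replaced a cyano-bearing one and gave a number 6 percentage points lower from compound 1 to compound 3 (within the scatter). Going by these compounds, on that basis compound 4 is expected to shift little from compound 2, by about a number 8 percentage points higher from compound 2 to compound 4 (within the scatter), though the change is untested and uncertainty is wide. Compound 4 is estimated at 38%, within 15% to 62%.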

Compound 4, a percentage reported as inhibition, at one concentration (the size of the read-out at that concentration, not a potency): 67%
For compound 4 the middle estimate is 29 percentage points below the measured one, outside the stated range (above it).
By their numbers in this assay, from the lowest: compound 2; then compounds 3, 1 and 4 (each within the scatter of the next, the first and the last beyond it).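

At the saturated chain carbon bound to three saturated chain carbons, with the chain held constant, this assay responds strongly to the end group: 1H-tetrazol-5-yl in place of cyano gives a number 37 percentage points higher from compound 2 to compound 4 (beyond the scatter). The earlier steps shown here changed the chain and the end group together, so they could not isolate this exchange. Nothing available accounts for the size of this step.

Going by these compounds, whether a carboxylic acid at this carbon would read like 1H-tetrazol-5-yl remains open. So does whether 1H-tetrazol-5-yl would have the same effect on the shorter chain of compound 1.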